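Imidazole to Methyltriazole: What Solubility Might Follow

This account rests on a few compounds, and the source may have more. Where it says the series, first, only, none or still open, it means among the compounds named here.

Compound 1, `Cc1cc(NCc2ccccn2)n2ncc(-c3ccc(F)cc3)c2n1`, gives < 5000 nM in a physicochemical assay for solubility, read by HPLC, using the shake flask method, measured as kinetic solubility, with a stated time of 2 h, at pH 7.4 (a lower number here means a less soluble compound, a higher number a more soluble compound), which is a limit of the assay rather than a number.
Compound 2, `Cc1cc(NCc2ncc[nH]2)n2nc(C)c(-c3ccccc3)c2n1`, gives < 5000 nM in this assay, again only a limit.
Compound 3, `Cc1cc(NCc2ccccn2)n2ncc(-c3ccco3)c2n1`, gives 48800 nM in this assay.

Compound 2 therefore stands at the lower limit of this assay, and compound 1 sits there too, so two of the three measured values are limits (the limit of < 5000 nM in this assay, at which 2 of the 3 values shown sit). Within the data shown here, only one measured step is known, an at least 9.7-fold higher number from compound 1 to compound 3 (0.98 log units; beyond the scatter), and it concerns the aromatic group on the core, not the part that changes here.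

Compound 4, `Cc1cc(NCc2ncnn2C)n2nc(C)c(-c3ccccc3)c2n1`, differs from compound 2 in one place: 1-methyl-1H-1,2,4-triazol-5-yl in place of 1H-imidazol-2-yl on a saturated chain carbon bound to a nitrogen on an aromatic ring. Among the measured compounds shown here, no measured step touches this position, so nothing among the numbers points to a direction, and a change no larger than the usual scatter is the plainest expectation. Because compound 2 shows only a limit, < 5000 nM, the step to compound 4 may again end at that limit.

Compound 4 is estimated at 6000 nM, within 1500 nM to 25000 nM. This estimate amounts to an at least 1.2-fold higher number from compound 2 to compound 4 (0.07 log units; that floor lies within the scatter).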

Compound 4, solubility: 185000 nM
Estimate against measurement, compound 4: 31-fold (1.49 log units) below; the measured number lies above the stated range.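

Placing 1-methyl-1H-1,2,4-triazol-5-yl in place of 1H-imidazol-2-yl on a saturated chain carbon bound to a nitrogen on an aromatic ring gives an at least 37-fold higher number from compound 2 to compound 4 (1.56 log units; beyond the scatter), so the group at this place can move the reading in this assay by a large amount, something the earlier step, which concerned only the aromatic group on the core, could not show. Compound 2 gives < 5000 nM, which is a limit and not a number. The step from it is therefore a floor, and its true size stays unknown: the limit of < 5000 nM in this assay, at which 2 of the 4 values shown sit.

The exchange alters the ring and its attached group together: the ring gains a nitrogen, and the hydrogen-bond donor of 1H-imidazol-2-yl gives way to a ring that carries a methyl group, so the compounds shown do not tell which of these differences goes with the higher number. Going by these compounds, two groups would pull these apart, 1-methyl-1H-imidazol-2-yl and the unmethylated 1H-1,2,4-triazol-5-yl, and it also remains open how the same exchange would read with the furan-2-yl or 4-fluorophenyl group on the core.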